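The source may hold more compounds than are shown below. What is called first, only, known or untested is meant among the compounds shown, and "the series" means these compounds.

Measured so far in an ADME assay on microsomes from liver (Rattus norvegicus) for metabolic stability, with a stated time of 10 min; on this read-out lower numbers stand for a less stable compound and higher numbers for a more stable compound:

- compound 1 `CC(C)(C)OC(=O)NCCS(=O)(=O)NC(=O)c1ccc(Nc2nc(NC3(c4ccc(Cl)cc4)CC3)nc(OCC(F)(F)F)n2)cc1`: 93%
- compound 2 `CN(C)S(=O)(=O)NC(=O)c1ccc(Nc2nc(NC3(c4ccc(Cl)cc4)CC3)nc(OCC(F)(F)F)n2)cc1`: 76%

Compound 2 stands lowest of the two numbers shown; the nearest value is that of compound 1, and the one measured step on the sulfonyl sulfur reads a number 17 percentage points lower from compound 1 to compound 2 (beyond the scatter). Compound 3 `Cc1ccccc1S(=O)(=O)NC(=O)c1ccc(Nc2nc(NC3(c4ccc(Cl)cc4)CC3)nc(OCC(F)(F)F)n2)cc1` is the next compound in this assay; it differs from compound 2 in that (2-methylphenyl in place of dimethylamino on a sulfonyl sulfur). The step from compound 1 to compound 2 is the only one that touches this position, and it exchanged two groups that differ from the present pair, so it gives a size but no direct reading for a 2-methylphenyl at this place. A step of comparable size in either direction, or none beyond the scatter, is therefore possible; the estimate leans toward a small decrease, a number 8 percentage points lower from compound 2 to compound 3 (within the scatter). For compound 3 the expected value in this assay is 68%, with a range from 40% to 90%.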

Compound 3, percent of the compound remaining: 100%
Beside the measured number, compound 3's estimate is 32 percentage points below it, outside the stated range (above it).
By their numbers in this assay, from the lowest: compound 2; then compounds 1 and 3 (each within the scatter of the next).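

In this assay, an aromatic ring on this sulfonyl sulfur carries no penalty: 2-methylphenyl in place of dimethylamino reads a number 24 percentage points higher from compound 2 to compound 3 (beyond the scatter). Against the chain of compound 1, the same ring reads a number 7 percentage points higher from compound 1 to compound 3 (within the scatter), so two very different groups, 2-((tert-butoxycarbonyl)amino)ethyl and 2-methylphenyl, sit within the scatter of each other, and among the three groups on this sulfur only dimethylamino stands apart. Nothing measured here accounts for the separation of dimethylamino from the other two groups.

Still open, from the compounds shown here alone, is whether the 2-methylphenyl reading belongs to the ring itself or depends on its methyl, which a plain phenyl or a 4-methylphenyl would separate. Also open, going by these compounds, is how a small alkyl group such as methyl, or an ethyl chain ending in a free amine or a carboxylic acid, would read at this sulfur.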